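Sulfonyl ring exchange from compound 2 to compound 4

The compounds below may be only part of what the source reports. "The series", "measured", "known", "first", "only" and "open" are said of these compounds alone.

Three measured compounds share one core. Compound 1 `CC(C)(C)c1cn(C[C@H](O)[C@H]2OC(=O)C(OCc3ccccc3)=C2OCc2ccccc2)nn1` gives 34000 nM in a functional assay on A549 cells (Homo sapiens) for antiproliferative activity, read by MTT assay, with a stated time of 72 h; a higher number here means a weaker inhibitor, a lower number a stronger inhibitor. Compound 2 `Cc1ccc(S(=O)(=O)NCc2cn(C[C@H](O)[C@H]3OC(=O)C(OCc4ccccc4)=C3OCc3ccccc3)nn2)cc1` gives 16800 nM, and compound 3 `O=C1O[C@H]([C@@H](O)Cn2cc(-c3cc(F)cc(F)c3)nn2)C(OCc2ccccc2)=C1OCc1ccccc1` gives 41200 nM. Compound 2 stands lowest of the three: a 2.0-fold lower number from compound 1 to compound 2 (0.31 log units; beyond the scatter), and a 2.5-fold higher number from compound 2 to compound 3 (0.39 log units; beyond the scatter). Compound 4 `O=C1O[C@H]([C@@H](O)Cn2cc(CNS(=O)(=O)c3ccc(Cl)cc3F)nn2)C(OCc2ccccc2)=C1OCc1ccccc1` differs from compound 2 by 4-chloro-2-fluorophenyl in place of 4-methylphenyl on a sulfonyl sulfur. Among the measured compounds shown here, no measured step alters the ring on the sulfonyl sulfur; the steps of a 2.0-fold lower number from compound 1 to compound 2 (0.31 log units; beyond the scatter) and a 1.2-fold higher number from compound 1 to compound 3 (0.08 log units; within the scatter) replace the whole group on the aromatic carbon and bear only loosely on this exchange. With the rest of compound 2 retained, compound 4 is expected to stay near compound 2, with a 1.1-fold lower number from compound 2 to compound 4 (0.02 log units; within the scatter) not expected to exceed the scatter. Compound 4 is estimated at 16000 nM. Its range is expected to run from 6000 nM to 42000 nM.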

Compound 4, half-maximal inhibitory concentration: 39100 nM
Estimate against measurement, compound 4: 2.4-fold (0.39 log units) below; the range from low to high includes it.
By their numbers in this assay, from the lowest: compound 2; then compounds 1, 4 and 3 (each within the scatter of the next).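

Among the compounds shown here, on the sulfonyl sulfur the ring itself matters in this assay: 4-chloro-2-fluorophenyl in place of 4-methylphenyl gives a 2.3-fold higher number from compound 2 to compound 4 (0.37 log units; beyond the scatter), whereas the earlier steps replaced the whole group on the aromatic carbon. The lowest number in the series, held by compound 2, therefore depends on the ring as well as on the sulfonamide link. No measured evidence bears on the reason for this step. For the compounds shown here, the single step cannot separate the chlorine from the fluorine of the entering ring. On these data alone, how a 4-methoxyphenyl or 4-aminophenyl ring on the sulfonyl sulfur would read remains open.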